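This account rests on a few compounds, and the source may have more. Where it says the series, first, only, none or still open, it means among the compounds named here.

The study examines compounds that bind the isolated kinase and measures them in an assay on isolated protein for inhibition of eIF-2-alpha kinase GCN2 (Homo sapiens); on this read-out lower numbers stand for stronger inhibition and higher numbers for weaker inhibition. Compound 1, with the structure `CCn1cc(Nc2ccn3ncc(-c4ccc(OC)cc4)c3n2)cn1`, is reported only as a limit of the assay: in this assay compound 1 gives > 1000 nM. This is the situation described by the limit of > 1000 nM in this assay, at which 1 of the 2 values shown sits. Within the data shown here, compound 2, with the structure `CCn1cc(Nc2ncc3c(C)nn(-c4ccc5ncccc5c4)c3n2)cn1`, is the one compound of the pair that returns an actual number, and in this assay compound 2 gives 23 nM. It therefore stands as the only measured value among the two results shown, the other being a limit.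

Compound 3, with the structure `Cc1nn(-c2ccc3ncccc3c2)c2nc(Nc3cnn(C4CCNCC4)c3)ncc12`, has not yet been measured in this assay. It differs from compound 2 in a single place: piperidin-4-yl in place of ethyl on an aromatic nitrogen. Among the measured compounds shown here, no pair of measured compounds shows this kind of change, so the size of the step is open. The author expects the step from compound 2 to compound 3 in this assay to be a 1.5-fold lower number from compound 2 to compound 3 (0.19 log units; within the scatter), a change that is expected to stay within or just beyond the usual scatter. Compound 3 is thus estimated to give 15 nM in this assay, within an expected range of 5 nM to 60 nM.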

Compound 3, half-maximal inhibitory concentration: 11 nM
The estimate for compound 3 lay 1.4-fold (0.13 log units) above the measured number; the range from low to high includes it.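

Putting piperidin-4-yl in place of ethyl on the aromatic nitrogen gives a 2.1-fold lower number from compound 2 to compound 3 (0.32 log units; beyond the scatter) in this assay. As the only single-place change among the compounds shown, it shows that this nitrogen can carry a group of 6 heavy atoms, with a six-membered non-aromatic ring and a hydrogen-bond donor, without any loss of inhibition; the number instead moves modestly in the favourable direction. No measurement among the compounds shown bears on why the number moves, and the step therefore stands here without an explanation.

The compounds shown leave open whether the ring nitrogen of piperidin-4-yl matters for this step or whether the ring alone would do, as neither a cyclohexyl group nor a tetrahydropyran-4-yl group on the same nitrogen stands among them. They also leave open how far this position extends, for instance to a piperidin-4-yl group with a methyl group on its ring nitrogen, to a longer chain such as n-butyl, or to a chain ending in a carboxylic acid.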